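This account rests on a few compounds, and the source may have more. Where it says the series, first, only, none or still open, it means among the compounds named here.

Measured so far:
compound 1 `CCCCCOC(=O)C(C)ON1C(=O)c2ccccc2C1=O` gives 64%
compound 2 `CCOC(=O)C(C)(C)ON1C(=O)c2ccccc2C1=O` gives 0%

In a functional assay on the whole organism for inhibition, with Lepidium sativum as the target, tested at 1 ppm (a higher number here means more inhibition of growth at the concentration tested, a lower number less inhibition of growth), compound 1 stands highest of the two numbers; compound 2 sits far lower, a gap beyond the usual scatter, though its structure differs from compound 1 in more than one place. Compound 3 `CCC(C)OC(=O)C(C)ON1C(=O)c2ccccc2C1=O` carries sec-butyl in place of pentyl on an oxygen next to a carbonyl group. Within the data shown here, no pair of measured compounds isolates such a change, so the size of the step can only be guessed: a modest loss is expected, a number 14 percentage points lower from compound 1 to compound 3 (beyond the scatter). Compound 3 is therefore expected to reach 50%, with a likely range from 25% to 70%.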

Compound 3, percent growth inhibition at one concentration: 42%
Compound 3: the middle estimate sits 8 percentage points above what was measured, and the stated range covers the measured number.
By their numbers in this assay, from the lowest: compound 2; then compound 3; then compound 1.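

In this assay, among these compounds, sec-butyl in place of pentyl on an oxygen next to a carbonyl group gives the first step that changes one place only (a number 22 percentage points lower from compound 1 to compound 3 (beyond the scatter)). Growth inhibition therefore responds to the group at this position, yet it does not vanish with this change: compound 3 still gives (42%). Nothing available here explains the loss.

The compounds shown leave open whether the loss goes with one carbon fewer or with the branching, as sec-butyl differs from pentyl in both. They also leave open how a straight butyl or a longer chain such as hexyl would behave on this oxygen.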